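Shortening the Hydroxyalkyl Chain: Expected Distribution Volume

A few compounds are considered here, and "the series" means these few. Any claim that something is new, unique, unknown or untested is made for them only; others in the source may bear on it.

Among the measured compounds shown here, compound 2 `CCCS(=O)(=O)Nc1ccc(F)c(-c2cc3cnc(NCCCO)nc3n(C)c2=O)c1F` gives 20 L/kg in an in vivo ADME assay on the whole organism for pharmacokinetics, with Mus musculus as the target, at a dose of 2.5 mg/kg by the intravenous route (a higher number here means that more of the compound sits outside the plasma, a lower number that more of the compound stays in the plasma), the highest of the two numbers measured so far; its nearest neighbour, compound 1 `CCCS(=O)(=O)Nc1ccc(F)c(-c2cc3cnc(NCC4CC4)nc3n(C)c2=O)c1F`, gives 0.46 L/kg in this assay. For the measured compounds named here, the one measured step, a 43-fold higher number from compound 1 to compound 2 (1.64 log units; beyond the scatter), concerns a different change at the same nitrogen. Compound 3 `CCCS(=O)(=O)Nc1ccc(F)c(-c2cc3cnc(NCCO)nc3n(C)c2=O)c1F` differs from compound 2 in that (hydroxy in place of hydroxymethyl on a saturated chain carbon, two bonds along the chain from a nitrogen on an aromatic ring), so the chain on the nitrogen on the aromatic ring becomes shorter while its hydroxy end is kept. Going by the values given here, no measured step covers such a shortening; the step from compound 1 to compound 2 shows only that the group on this nitrogen can move the number a great deal, and it does not say what a shorter chain with the same hydroxy end does. A number near that of compound 2, perhaps somewhat lower, is therefore expected, namely a 2.0-fold lower number from compound 2 to compound 3 (0.30 log units; within the scatter). Compound 3 is estimated at 10 L/kg, within a range from 2.5 L/kg to 40 L/kg.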

Compound 3, volume of distribution: 1 L/kg
Beside the measured number, compound 3's estimate is 10-fold (1.00 log units) above it; measured number outside the range, below it.
By their numbers in this assay, from the lowest: compound 1; then compound 3; then compound 2.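

In this assay, the length of the hydroxyalkyl chain on this nitrogen matters on its own: going from 3-hydroxypropyl to 2-hydroxyethyl, with the hydroxy end kept, gives a 20-fold lower number from compound 2 to compound 3 (1.30 log units; beyond the scatter), a large step for so small a change. The earlier pair showed only that swapping cyclopropyl for a hydroxy-bearing chain could move the number, and it could not separate the hydroxy end from the chain length. The shorter chain now gives only a 2.2-fold higher number from compound 1 to compound 3 (0.34 log units; beyond the scatter), so among these compounds a hydroxy end alone does not bring the very high number, which appears only with 3-hydroxypropyl.

Nothing shown here accounts for these steps. Still open, as far as these compounds go, is whether a longer chain would raise the number further, and whether an amine or a carboxylic acid at the chain end would act as the hydroxy does.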